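Hydrogen for methyl on the sulfonamide nitrogen

A few compounds are considered here, and "the series" means these few. Any claim that something is new, unique, unknown or untested is made for them only; others in the source may bear on it.

Among the measured compounds shown here, compound 1 `CN(Cc1ccccc1)S(=O)(=O)c1ccc(NC(=O)NCc2ccncc2)cc1` is the only compound of this set with a number in an assay on isolated protein for activation of Nicotinamide phosphoribosyltransferase (Homo sapiens); on this read-out higher numbers stand for an effect only at larger amounts of compound and lower numbers for an effect already at smaller amounts: compound 1 gives 23 nM. Compound 2 `CCOC(=O)c1ccc(NC(=O)NCc2ccnnc2)cc1` carries no number but a limit of the assay; in this assay compound 2 stands at > 100000 nM, a limit and not a value (the limit of > 100000 nM in this assay, at which 1 of the 2 values shown sits). For the measured compounds named here, compound 2 differs from compound 1 in more than one place, so no single step can be drawn between them; their two results show only that compound 1 yields a number where compound 2 yields a limit.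

The compound still to be measured is compound 3 `O=C(NCc1ccncc1)Nc1ccc(S(=O)(=O)NCc2ccccc2)cc1`. It differs from compound 1 in one place: hydrogen in place of methyl on a sulfonamide nitrogen. Going by the values given here, no measured pair in this set shows this change, so the size of the step rests on compound 1 alone. The expected step is one that stays within the scatter, perhaps a slight loss, written as a 1.7-fold higher number from compound 1 to compound 3 (0.24 log units; within the scatter). Compound 3 is therefore estimated at 40 nM, with a range from 10 nM to 160 nM.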

Compound 3, half-maximal effective concentration: 102 nM
Compound 3: middle estimate off by 2.6-fold (0.41 log units), on the low side; the range from low to high includes it.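

In this assay, among the compounds shown here, the methyl on the sulfonamide nitrogen turns out to matter: hydrogen in its place gives a 4.4-fold higher number from compound 1 to compound 3 (0.65 log units; beyond the scatter), the first step in this set that can be read at this position. Going from benzyl(methyl)amino to benzylamino removes a single carbon and no ring, yet that is enough for a step beyond the usual scatter, while compound 3 still gives a number and not a limit. Nothing shown here accounts for the size of this step, and the single limit in the set belongs to a compound that differs from both of these in more than one place.

On these data alone, the reading rests on one pair, so it remains open whether the trend continues from hydrogen through methyl to an ethyl group, a longer chain or a cyclopropyl group on this nitrogen. Also open, as far as these compounds go, is whether the benzyl group on the same nitrogen is needed at all, or could give way to a morpholine or a simple amine while the core of compound 1 stays unchanged.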